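The source may report more compounds than this note shows. Statements on the series, on what has been measured and on what is new or still open speak of the compounds shown alone.

Four compounds are compared here, all built on one shared core with a bromonaphthyl ether and a chlorophenyl group. Compound 1 `O=C(Nc1ncc(C(Oc2ccc3cc(Br)ccc3c2)c2ccc(Cl)cc2)s1)c1ccccc1` and compound 2 `O=C(Nc1ncc(C(Oc2ccc3cc(Br)ccc3c2)c2ccc(Cl)cc2)s1)c1ccc(Cl)nc1` carry an amide on the core. In an ADME assay on HepG2 2.2.15 cells (Homo sapiens) for cytotoxicity (on this read-out lower numbers stand for higher toxicity in this test and higher numbers for lower toxicity in this test), compound 1 gives "not toxic" (no number reported). In this assay compound 2 gives "not toxic" (no number reported). Compound 3 `CCc1ccc(S(=O)(=O)Nc2ncc(C(Oc3ccc4cc(Br)ccc4c3)c3ccc(Cl)cc3)s2)cc1` carries a sulfonamide in place of the amide. In this assay the value of compound 3 is a limit of the assay and not a number: > 50000 nM. So compound 3 stands at the upper edge of the scale, as described by the limit of > 50000 nM in this assay, at which 1 of the 3 values shown sits, and it cannot be placed more exactly than that.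

Compound 4 `O=S(=O)(Nc1ncc(C(Oc2ccc3cc(Br)ccc3c2)c2ccc(Cl)cc2)s1)c1ccc2ccccc2c1` differs from compound 3 in one place: naphthalen-2-yl in place of 4-ethylphenyl on a sulfonyl sulfur. Among the measured compounds shown here, no measured pair in this set isolates such a change, so there is no measured step to lean on. Both compounds keep the sulfonamide, and compound 3 showed no toxicity up to the limit of the assay, so the expected step from compound 3 to compound 4 in this assay is none beyond the usual scatter. The expected step is a step that the limit leaves unreadable from compound 3 to compound 4. For compound 4 the estimated half-maximal cytotoxic concentration is 60000 nM, with a range from 20000 nM to 200000 nM.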

Compound 4, half-maximal cytotoxic concentration: > 50000 nM
Compound 4: no number, only a limit (the forecaster's own chance of this, stated with the estimate: 80%); the middle value lies beyond the limit too.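

No step can be read between compound 3 and compound 4, since both stop at the same value, which is a limit of the assay and not a number: the limit of > 50000 nM in this assay, at which 2 of the 4 values shown sit.

The compounds shown leave open at what concentration any of them would become toxic to these cells, and whether naphthalen-2-yl and 4-ethylphenyl on a sulfonyl sulfur differ at all.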